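The compounds below may be only part of what the source reports. "The series", "measured", "known", "first", "only" and "open" are said of these compounds alone.

Working notes on the series.

Compound 3 `C#CCc1c(Cl)cc(N/C=N/OCCCC)cc1Cl` stands at 4.4 in a physicochemical assay for lipophilicity, measured as octanol-water partition; on this read-out lower numbers stand for lower lipophilicity and higher numbers for higher lipophilicity. Compound 2 `CCCOc1c(Cl)cc(N/C=N/OCC)cc1Cl` gives 4.6 in this assay, which lies within the scatter of the value of compound 3, so no order between compound 2 and compound 3 is claimed. Compound 1 `CCO/N=C/Nc1cc(Cl)c(SSCC)c(Cl)c1` gives 5 in this assay, a value beyond the scatter above that of compound 3. Among the measured compounds shown here, the one step between measured compounds that differ in a single place is a number 0.40 log units lower from compound 1 to compound 2 (beyond the scatter), a change on an aromatic carbon.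

Compound 4 `C#CCc1c(Cl)cc(N/C=N/OC/C=C\Cl)cc1Cl` is not yet measured in this assay. It differs from compound 3 by 2-chloroethenyl in place of propyl on a saturated chain carbon bound to an oxygen. For the measured compounds named here, no measured step touches the chain bound to the oxygen; the step from compound 1 to compound 2 sits on an aromatic carbon and does not bear on this change, so the expectation rests on the close match in the count of heavy atoms that leave and enter, with one chlorine entering in place of one carbon. The expected step is therefore small, a number 0.10 log units lower from compound 3 to compound 4 (within the scatter), and is not expected to go beyond the scatter in either direction. Compound 4 is estimated at 4.3 in this assay, with a range from 3.9 to 4.7.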

Compound 4, partition coefficient: 3.9
For compound 4 the middle estimate is 0.40 log units above the measured one; the range from low to high includes it.
By their numbers in this assay, from the lowest: compound 4; then compounds 3 and 2 (each within the scatter of the next); then compound 1.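

Among the compounds shown here, the chain bound to the oxygen now has a measured step of its own: with 2-chloroethenyl in place of propyl on a saturated chain carbon bound to an oxygen, this assay gives a number 0.50 log units lower from compound 3 to compound 4 (beyond the scatter), whereas the only earlier step sat on an aromatic carbon. The heavy-atom count is the same for the leaving and entering groups, so on this pair that count alone does not fix the read-out at this place. The entering group brings both a chlorine and a double bond, this single pair cannot separate the two, and nothing measured here accounts for the step.

Still open, on these data alone, is which of the two changes carries the step, a question that a plain prop-2-en-1-yl or a saturated 3-chloropropyl group on the same oxygen would address. Also open, as far as these compounds go, are whether the step carries over to the core of compound 2, with its propoxy group, and how a longer chain, an amine or a carboxylic acid at this place would read in this assay.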